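Methyl for Phenylsulfanyl on a Fused Five-Membered Ring

The source may hold more compounds than are shown below. What is called first, only, known or untested is meant among the compounds shown, and "the series" means these compounds.

Measured compounds: compound 1 `COc1cc(OCc2ccccc2OC)c2cc(-c3cn4nc(OC)sc4n3)oc2c1`, 19 nM; compound 2 `c1ccc(Sc2nn3cc(-c4cc5ccccc5o4)nc3s2)cc1`, 1900 nM; compound 3 `COc1cc(OCc2cccc(O)c2)c2cc(-c3cn4nc(OC)sc4n3)oc2c1`, 3.1 nM.

In a functional assay on HEK293 cells for antagonist activity at proteinase-activated receptor 4 (Homo sapiens), read by FLIPR and calcium flux, with a stated time of 30 min (on this read-out higher numbers stand for weaker inhibition and lower numbers for stronger inhibition), compound 2 gives the highest of the three numbers; compound 1 lies a long way lower, and compound 3 lower still. Going by the values given here, the only single-point step, a 6.1-fold lower number from compound 1 to compound 3 (0.79 log units; beyond the scatter), concerns the benzylic part of the shared core and so does not bear on the change studied here.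

Compound 4 `Cc1nn2cc(-c3cc4ccccc4o3)nc2s1` differs from compound 2 by methyl in place of phenylsulfanyl on an aromatic carbon. Among the compounds with values here, no measured step covers this exchange, and compounds 1 and 3 differ from compound 2 in more than one place. The account therefore expects, for compound 4, a number near that of compound 2, with a 1.3-fold lower number from compound 2 to compound 4 (0.10 log units; within the scatter) as the estimated step. Compound 4 is estimated at 1500 nM (range 300 nM to 7000 nM).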

Compound 4, half-maximal inhibitory concentration: 37 nM
Beside the measured number, compound 4's estimate is 41-fold (1.61 log units) above it; measured number below the stated range.
By their numbers in this assay, from the lowest: compound 3; then compounds 1 and 4 (each within the scatter of the next); then compound 2.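

In this assay, replacing phenylsulfanyl with methyl on this aromatic carbon, next to the ring nitrogen and next to the ring sulfur, gives a 51-fold lower number from compound 2 to compound 4 (1.71 log units; beyond the scatter). So the phenylsulfanyl group, with its six-membered aromatic ring, is not required at this position for a low number, and the much smaller methyl serves far better on this core. Nothing available accounts for the size of this step.

Going by these compounds, how an amine or a longer chain such as ethyl would read at this position remains open. So does whether the same exchange would give a step of similar size on the core of compound 1.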